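A few compounds are considered here, and "the series" means these few. Any claim that something is new, unique, unknown or untested is made for them only; others in the source may bear on it.

Measured so far:
- compound 1, `Cc1nc2c([nH]1)C(=O)/C(=N/c1ccc(F)c(F)c1F)C(Cl)=C2O`: 1600 nM in a functional assay on NIH3T3 cells (Mus musculus) for antiproliferative activity; a lower number here means a stronger inhibitor, a higher number a weaker inhibitor
- compound 2, `Cc1nc2c([nH]1)C(=O)/C(=N/c1cccc(Cl)c1)C(Cl)=C2O`: 1600 nM in this assay

Compound 2 stands level with compound 1 at the digits shown. The two values lie within the scatter of one another, so no order between them can be read, and neither compound can be called the more active. Among the measured compounds shown here, no step between measured compounds that differ in a single place is available in this set, so the series so far gives no calibrated change of any kind.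

Compound 3, `Cc1nc2c([nH]1)C(=O)/C(=N/c1cccc(Br)c1)C(Cl)=C2O`, remains to be measured in this assay. It differs from compound 2 by bromo in place of chloro on an aromatic carbon. For the measured compounds named here, with two measured compounds that sit together and no step of this sort on record, the size of the change in this assay cannot be taken from the data; the working expectation is none beyond the scatter. The expected step is no change at the digits printed from compound 2 to compound 3 (within the scatter). For compound 3 the estimate in this assay is 1600 nM, with a range from 800 nM to 3200 nM.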

Compound 3, half-maximal inhibitory concentration: 800 nM
Beside the measured number, compound 3's estimate is 2.0-fold (0.30 log units) above it; the measured number falls inside the stated range.
By their numbers in this assay, from the lowest: compounds 3, 1 and 2 (each within the scatter of the next).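

The series now holds its first step in a single place, 3-chlorophenyl to 3-bromophenyl, and in this assay it reads a 2.0-fold lower number from compound 2 to compound 3 (0.30 log units; within the scatter). At this position on the six-membered aromatic ring, the exchange of chloro for bromo therefore gives no difference that can be separated from the scatter, so compounds 2 and 3 cannot be placed in any order, and this one step is the series' only calibration of a change at this position. Nothing on hand bears on why the exchange behaves this way.

Among the compounds shown here, the single step spans only two halogens, so how this position responds to a different kind of group, such as an amine, a carboxylic acid or a longer chain, remains open. Also open, going by these compounds, is whether the same exchange of chloro for bromo would read the same way elsewhere on this aromatic ring or at the chloro carried by the shared core.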